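Bromo in Place of Methyl: Expectation for Compound 4

The compounds below may be only part of what the source reports. "The series", "measured", "known", "first", "only" and "open" are said of these compounds alone.

In an assay on isolated protein for inhibition of Amine oxidase [flavin-containing] A (Homo sapiens), read by fluorescence, with a stated time of 15 min (on this read-out lower numbers stand for stronger inhibition and higher numbers for weaker inhibition), compound 3 `COc1ccc(/C=C/c2cc(OC)cc(OC)c2/C=C/C(=O)c2cc3ccc(C)cc3oc2=O)cc1` gives 58200 nM, the highest of the two numbers reported. Compound 2 `COc1ccc(/C=C/c2cc(OC)cc(OC)c2/C=C/C(=O)c2cc3ccc(Br)cc3oc2=O)cc1` gives 3010 nM in this assay. For compound 1 `COc1ccc(/C=C/c2cc(OC)cc(OC)c2/C=C/C(=O)c2cc3cc(OC)ccc3oc2=O)cc1` this assay reports only a limit, > 60000 nM. Compound 4 `COc1ccc(/C=C/c2cc(OC)cc(OC)c2/C=C/C(=O)c2cc3cc(Br)ccc3oc2=O)cc1` differs from compound 3 by a group of 12 heavy atoms (9 carbon, 2 oxygen, 1 bromine; one six-membered aromatic ring of carbon only, one six-membered aromatic ring with 1 hetero atom) in place of a group of 12 heavy atoms (10 carbon, 2 oxygen; one six-membered aromatic ring of carbon only, one six-membered aromatic ring with 1 hetero atom), on a carbonyl carbon, so bromo again takes the place of methyl, though at another position on the same group. Among the measured compounds shown here, the one measured step that bears on this is a 19-fold higher number from compound 2 to compound 3 (1.29 log units; beyond the scatter), a large change. A step in the opposite direction, towards a lower number, is therefore expected for compound 4, with less confidence in its size since the bromo sits elsewhere. The estimate for compound 4 in this assay is 6000 nM, expected to fall between 1500 nM and 30000 nM. This corresponds to an expected step of a 9.7-fold lower number from compound 3 to compound 4 (0.99 log units; beyond the scatter).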

Compound 4, half-maximal inhibitory concentration: 12100 nM
Compound 4: the middle estimate sits 2.0-fold (0.30 log units) below what was measured; the range from low to high includes it.
By their numbers in this assay, from the lowest: compound 2; then compound 4; then compound 3. At a limit, above all of these: compound 1.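

In this assay, bromo at the other position on the same group still gives a lower number than the methyl, a 4.8-fold lower number from compound 3 to compound 4 (0.68 log units; beyond the scatter), but a higher one than the earlier bromo placement, a 4.0-fold higher number from compound 2 to compound 4 (0.60 log units; beyond the scatter), so where the bromo sits matters as well as whether it is present. Bromo in place of methoxy gives an at least 4.9-fold lower number from compound 1 to compound 4 (0.69 log units; beyond the scatter), a step read only against a limit. Compound 1 stands at that limit: the limit of > 60000 nM in this assay, at which 1 of the 4 values shown sits.

On these data alone, it remains open how a methyl would compare with the bromo at the position held in compound 4. As far as these compounds go, it also remains open what an amine or a carboxylic acid would do at either position.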